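Alkynyl-to-alkenyl pyridine swap on the piperidine series

The compounds below may be only part of what the source reports. "The series", "measured", "known", "first", "only" and "open" are said of these compounds alone.

Measured compounds:
compound 1 `Cc1ccc(-n2nccn2)c(C(=O)N2C[C@H](C#Cc3cccnc3)CC[C@H]2C)c1`: 28 nM
compound 2 `Cc1ccc(-n2nccn2)c(C(=O)N2C[C@H](C#Cc3ccc(CO)nc3)CC[C@H]2C)c1`: "not determined" (no result reported)

In a functional assay on isolated protein for antagonist activity at Orexin receptor type 2 (Homo sapiens), read by FLIPR and calcium flux (on this read-out higher numbers stand for weaker inhibition and lower numbers for stronger inhibition), compound 1 gives 28 nM. For compound 2, which carries the 2-(6-(hydroxymethyl)pyridin-3-yl)ethynyl group, the result in this assay is "not determined" (no result reported), so compound 2 has no number to stand on; the only anchor in this assay is compound 1.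

Compound 3 `Cc1ccc(-n2nccn2)c(C(=O)N2C[C@H](/C=C/c3ccc(F)cn3)CC[C@H]2C)c1` is not yet measured. It differs from compound 2 by 2-(5-fluoropyridin-2-yl)ethenyl in place of 2-(6-(hydroxymethyl)pyridin-3-yl)ethynyl on a saturated ring carbon. Among the measured compounds shown here, no step between measured compounds is available, so the size and direction of the change from compound 2 to compound 3 in this assay cannot be read from the data; the expectation is a step of no more than the usual scatter in either direction, anchored on compound 1.

Compound 3 is estimated at 35 nM, with a range from 8 nM to 150 nM in this assay.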

Compound 3, half-maximal inhibitory concentration: 34 nM
The estimate for compound 3 lay 1.0-fold (0.01 log units) above the measured number; low and high end bracket the measured number.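

In this assay, among the compounds shown here, 2-(5-fluoropyridin-2-yl)ethenyl in place of 2-(pyridin-3-yl)ethynyl on the saturated ring carbon gives a 1.2-fold higher number from compound 1 to compound 3 (0.08 log units; within the scatter), the first readable step at this position. For these two compounds, the exchange of the triple bond for a double bond, the different pyridine attachment and the added fluorine together produce no change beyond the scatter, but this single step cannot separate the three differences. No measurement at hand accounts for this result.

On these data alone, the step from compound 2 to compound 3 cannot be read, so the contribution of the hydroxymethyl group of compound 2 remains unknown. Also open, as far as these compounds go, is how an amine or a carboxylic acid in place of the fluorine of compound 3 would read in this assay.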